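Phenyl Added at the Benzylic Carbon of Compound 1

A few compounds are considered here, and "the series" means these few. Any claim that something is new, unique, unknown or untested is made for them only; others in the source may bear on it.

Working notes on a small series measured in an assay on PC-12 cells for binding affinity to Nischarin (Rattus norvegicus); a lower number here means a stronger inhibitor, a higher number a weaker inhibitor. Compound 1 `c1ccc(CCC2=NCCN2)cc1` gives 3720 nM, the highest of the three numbers recorded so far. Compound 2 `C1CN=C(NC(C2CC2)C2CC2)C1` gives 513 nM in this assay, and compound 3 `COC1=NC(C)(Cl)CC=C1NC1=NCCN1` gives 33.9 nM. Compound 1 therefore stands at the weak end of what has been measured, and its gaps to compound 2 and to compound 3 are both beyond the usual scatter.

Compound 4 `c1ccc(C(CC2=NCCN2)c2ccccc2)cc1` is the next compound to be measured. It differs from compound 1 by phenyl in place of hydrogen on a saturated chain carbon bound to an aromatic carbon and a saturated chain carbon. Among the compounds with values here, no measured pair shows this change, so its size has no precedent here; compound 2 and compound 3 belong to different scaffolds and say nothing about adding a phenyl to the chain of compound 1. The step from compound 1 to compound 4 is expected to be modest and toward a lower number, a 2.1-fold lower number from compound 1 to compound 4 (0.32 log units; beyond the scatter), and it may not clear the scatter. Compound 4 is accordingly estimated at 1800 nM in this assay, with a range from 500 nM to 6500 nM.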

Compound 4, inhibition constant: 3090 nM
Estimate against measurement, compound 4: 1.7-fold (0.23 log units) below; measured number inside the range.
By their numbers in this assay, from the lowest: compound 3; then compound 2; then compounds 4 and 1 (each within the scatter of the next).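

Within the data shown here, the one step read at this position is a 1.2-fold lower number from compound 1 to compound 4 (0.08 log units; within the scatter) in this assay, so phenyl in place of hydrogen on a saturated chain carbon bound to an aromatic carbon and a saturated chain carbon gives no change that can be told from the scatter. Among these compounds, the series had no earlier pair at this carbon, and this pair shows that the carbon accepts an entering group of 6 heavy atoms, one six-membered aromatic ring of carbon only, with the number held within the scatter of that of compound 1. Nothing available bears on why the number holds, and the result carries no explanation.

The compounds shown leave open whether a smaller group on this same carbon, such as methyl, hydroxyl or an amine, would give a step beyond the scatter, since a single entering group cannot show how the number responds across different groups at this position. They also leave open whether a longer chain in the core of compound 1 would move the number, with or without the added phenyl.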